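A few compounds are considered here, and "the series" means these few. Any claim that something is new, unique, unknown or untested is made for them only; others in the source may bear on it.

Of the compounds shown here, two built on one shared core have been measured in an assay with adenosine receptor A1 (Rattus norvegicus) as the target; a lower number here means that less compound is needed, a higher number that more compound is needed for the effect. Compound 1 `Nc1sc2c(c1C(=O)c1ccc(C(F)(F)F)cc1)CCCC2` gives 4700 nM, while compound 2 `Nc1sc2c(c1C(=O)c1ccc(Br)cc1)CCCC2` gives 16400 nM, the highest of the two numbers; that step, a 3.5-fold higher number from compound 1 to compound 2 (0.54 log units; beyond the scatter), came with bromo in place of trifluoromethyl. Compound 3 `Nc1sc2c(c1C(=O)c1ccc(I)cc1)CCCC2` differs from compound 2 only by iodo in place of bromo on an aromatic carbon. Going by the values given here, no measured step exchanges bromo for iodo, so only a 3.5-fold higher number from compound 1 to compound 2 (0.54 log units; beyond the scatter) touches this position, and it compares different groups. For compound 3 the expected step is a 1.0-fold lower number from compound 2 to compound 3 (0.01 log units; within the scatter), not beyond the scatter. Compound 3 is therefore estimated at 16000 nM, within 6000 nM to 40000 nM.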

Compound 3, half-maximal effective concentration: 4500 nM
Compound 3: middle estimate off by 3.6-fold (0.55 log units), on the high side; measured number outside the range, below it.
By their numbers in this assay, from the lowest: compounds 3 and 1 (each within the scatter of the next); then compound 2.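

In this assay iodo in place of bromo gives a 3.6-fold lower number from compound 2 to compound 3 (0.56 log units; beyond the scatter), so exchanging one single atom for another at this position can move the number beyond the scatter. Iodo in place of trifluoromethyl gives only a 1.0-fold lower number from compound 1 to compound 3 (0.02 log units; within the scatter), which leaves bromo as the one group of the three that stands apart. No measurement shown here offers a reason for this. Going by these compounds, what an amine or a carboxylic acid at this position would give stays open. So does whether the gap between bromo and iodo holds on a different core.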